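Replacing Acetyl with 1,1-Difluoroethyl on Compound 3

A few compounds are considered here, and "the series" means these few. Any claim that something is new, unique, unknown or untested is made for them only; others in the source may bear on it.

In an ADME assay on HepG2 cells (Homo sapiens) for cytotoxicity (a higher number here means that more compound is tolerated, a lower number that less compound is tolerated), compound 3 `CC(=O)c1cccc(N2C(=O)CN(c3cccc(C(F)(F)F)c3)CC2C(=O)NC2CCCC2)c1` gives 40000 nM, the higher of the two numbers available, and compound 2 `CSc1cccc(N(CC(=O)NC2CCCC2)C(=O)c2cc3ccc(C(F)(F)F)cc3n2C)c1` gives 6300 nM, a gap beyond the scatter. The result for compound 1 `CSc1cccc(N2C(=O)c3ccc(-c4ccco4)n3CC2(C)C(=O)NC2CCCC2)c1` is a limit of the assay, > 50000 nM. Compound 4 `CC(F)(F)c1cccc(N2C(=O)CN(c3cccc(C(F)(F)F)c3)CC2C(=O)NC2CCCC2)c1` has 1,1-difluoroethyl in place of acetyl on an aromatic carbon, and the rest of compound 3 is kept. Among the measured compounds shown here, no two measured compounds differ in one place, so the expectation in this assay is only a cautious one. The estimated step of a 1.6-fold lower number from compound 3 to compound 4 (0.20 log units; within the scatter) is small, towards a lower number and within the scatter. For compound 4 the estimated value is 25000 nM, with an expected range of 10000 nM to 50000 nM.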

Compound 4, half-maximal cytotoxic concentration: 9000 nM
For compound 4 the middle estimate is 2.8-fold (0.44 log units) above the measured one; measured number below the stated range.
By their numbers in this assay, from the lowest: compounds 2 and 4 (each within the scatter of the next); then compound 3. At a limit, above all of these: compound 1.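

Among the compounds shown here, the first step between two compounds that differ in one place shows that this site, on an aromatic carbon meta to a large group, is not indifferent in this assay: 1,1-difluoroethyl in place of acetyl gives a 4.4-fold lower number from compound 3 to compound 4 (0.65 log units; beyond the scatter). With the rest of compound 3 kept, this single exchange moves the tolerated concentration beyond the scatter. The value of compound 1 remains a limit of the assay: the limit of > 50000 nM in this assay, at which 1 of the 4 values shown sits.

From the compounds shown here alone, whether the change follows from losing the carbonyl or from gaining fluorine stays open. So does what a methoxy group or an amine would give at this site.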